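The source may report more compounds than this note shows. Statements on the series, on what has been measured and on what is new or still open speak of the compounds shown alone.

Working notes on the series in an assay for positive allosteric modulation of metabotropic glutamate receptor 3 (Rattus norvegicus); a lower number here means that less compound is needed, a higher number that more compound is needed for the effect. Compound 1 `COc1ccc(C(=O)O)cc1O[C@@H](C)COc1ccc(C(=O)CC(C)(C)C)c(O)c1C` gives 2210 nM in this assay. Compound 2 `COc1ccc(C(=O)O)cc1OC[C@@H](C)Oc1ccc(C(=O)CC(C)(C)C)c(O)c1C` gives 806 nM. Compound 3 `Cc1ccc(OC[C@H](C)COc2ccc(C(=O)CC(C)(C)C)c(O)c2C)cc1C(=O)O` returns only a limit, > 10000 nM, so no number stands for it; it sits at the limit of > 10000 nM in this assay, at which 1 of the 3 values shown sits, and is the one of the three that is not placed on the scale. Nothing more can be said of where compound 3 stands than that it lies at that limit.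

Compound 4 `Cc1c(OC[C@@H](C)COc2ccc3c(c2)C(=O)NC3)ccc(C(=O)CC(C)(C)C)c1O` has not been measured. It differs from compound 3 by a group of 10 heavy atoms (8 carbon, 1 nitrogen, 1 oxygen; one five-membered non-aromatic ring with 1 hetero atom, one six-membered aromatic ring of carbon only) in place of a group of 10 heavy atoms (8 carbon, 2 oxygen; one six-membered aromatic ring of carbon only), on an oxygen on a saturated carbon, on an oxygen on a saturated carbon whose other neighbours are a saturated chain carbon. Within the data shown here, no step between two measured compounds covers this kind of change, and the evidence on compound 3 is a limit only, so no measured step gives a direction. The expectation for compound 4 in this assay is a value near the upper part of the range seen for compound 1 and compound 2, which would mean a step of an at least 2.8-fold lower number from compound 3 to compound 4 (0.45 log units; beyond the scatter) downward from the limit of compound 3, though a second limit remains a real possibility. The estimate for compound 4 is 3500 nM, with a range from 700 nM to 15000 nM.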

Compound 4, half-maximal effective concentration: "not active" (no number reported)
The entry for compound 4 holds no number, so the estimate cannot be set against anything.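

Among these compounds, compound 4 is reported as "not active" with no number, so no step from compound 3 to compound 4 can be read. Compound 3 holds only a limit: the limit of > 10000 nM in this assay, at which 1 of the 4 values shown sits. The compounds shown leave open whether either of these two groups, at this place, can give a value on the scale.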